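This account rests on a few compounds, and the source may have more. Where it says the series, first, only, none or still open, it means among the compounds named here.

Measured in an assay on isolated protein for inhibition of protein deacetylase HDAC6 (Homo sapiens), read by fluorescence, with a stated time of 1 h, tested at 100 nM; a higher number here means more inhibition at the concentration tested (going by the name of the read-out), a lower number less inhibition:
Compound 1 `C=CCN1CCC(c2noc(COc3ccc(/C=C/C(=O)NO)cc3)n2)CC1` gives 66%.
Compound 2 `O=C(/C=C/c1ccc(OCc2nc(C3CCN(Cc4ccc(F)cc4)CC3)no2)cc1)NO` gives 75%.
Compound 3 `O=C(/C=C/c1ccc(OCc2nc(C3CCN(Cc4ccc(F)cc4F)CC3)no2)cc1)NO` gives 74%.

Compound 3 sits among the other two on these numbers without standing apart from either: a number 1 percentage points lower from compound 2 to compound 3 (within the scatter), and a number 8 percentage points higher from compound 1 to compound 3 (within the scatter). The three values are therefore indistinguishable at the usual scatter.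

Compound 4 `COc1ccc(CN2CCC(c3noc(COc4ccc(/C=C/C(=O)NO)cc4)n3)CC2)cc1` differs from compound 3 in one place: 4-methoxyphenyl in place of 2,4-difluorophenyl on a saturated chain carbon bound to an amine nitrogen in a ring. Among the compounds with values here, no measured step replaces fluorine on that aromatic ring by a methoxy group. The steps that come closest are the two that put an aryl group onto the same saturated chain carbon in place of vinyl, a number 9 percentage points higher from compound 1 to compound 2 (within the scatter) and a number 8 percentage points higher from compound 1 to compound 3 (within the scatter), and the one that varies the fluorine pattern on that ring, a number 1 percentage points lower from compound 2 to compound 3 (within the scatter). All three stayed within the scatter, so a change of substituent on this ring has so far left the reading unchanged, and the same is expected here: compound 4 is estimated to show a number 1 percentage points lower from compound 3 to compound 4 (within the scatter), nothing beyond the scatter. The value of compound 4 is expected to be about 73%, in the range 60% to 85%.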

Compound 4, a percentage reported as inhibition, at one concentration (the size of the read-out at that concentration, not a potency): 75%
For compound 4 the middle estimate is 2 percentage points below the measured one; measured number inside the range.
By their numbers in this assay, from the lowest: compounds 1, 3, 2 and 4 (each within the scatter of the next).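

In this assay, the exchange of 2,4-difluorophenyl for 4-methoxyphenyl on the saturated chain carbon bound to the ring amine nitrogen gives a number 1 percentage points higher from compound 3 to compound 4 (within the scatter), and the simpler exchange of fluoro for methoxy on the aromatic carbon gives no change at the digits printed from compound 2 to compound 4 (within the scatter). Thus a methoxy-bearing ring, which counts one hydrogen-bond acceptor where the fluorinated rings count none, reads like those rings here, and its comparison with the vinyl group gives a number 9 percentage points higher from compound 1 to compound 4 (within the scatter). Nothing available explains why these readings coincide.

Going by these compounds, with all readings this close at one tested concentration, it remains open whether any substituent on this ring affects inhibition. A ring bearing an amine or a carboxylic acid, or a longer chain in place of the benzyl group, might read differently.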